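A few compounds are considered here, and "the series" means these few. Any claim that something is new, unique, unknown or untested is made for them only; others in the source may bear on it.

The measured compounds:
Compound 1 `COc1ccc(-c2ccc(C(=O)NCCCCc3cccnc3)cc2OC)cc1OC` — in an assay (Canis lupus familiaris) for binding affinity to platelet-activating factor receptor (Homo sapiens), read by radioligand binding (on this read-out higher numbers stand for weaker inhibition and lower numbers for stronger inhibition), compound 1 gives 300 nM.
Compound 2 `COc1cccc(-c2ccc(C(=O)NCCCCc3cccnc3)cc2)c1` — in this assay compound 2 gives 280 nM.
Compound 3 `Cc1ccc(-c2ccc(C(=O)NCCCCc3cccnc3)cc2)cc1C` — in this assay compound 3 gives 200 nM.

Compound 2 holds the second highest of the three numbers; its nearest neighbour is compound 1, and the gap between them lies within the scatter, as does the gap to compound 3. For the measured compounds named here, the one measured step that changes the same part of the molecule is that from compound 2 to compound 3, where 3,4-dimethylphenyl replaces 3-methoxyphenyl: a 1.4-fold lower number from compound 2 to compound 3 (0.15 log units; within the scatter). Compound 4 `COc1ccc(-c2ccc(C(=O)NCCCCc3cccnc3)cc2)cc1OC` is not yet measured. It differs from compound 2 in one place: methoxy in place of hydrogen on an aromatic carbon. Because the step of a 1.4-fold lower number from compound 2 to compound 3 (0.15 log units; within the scatter) stayed within the scatter, and because compound 1, which also carries an added methoxy group, gives 300 nM, no step beyond the scatter is expected in this assay in either direction. The expected step from compound 2 is a 1.0-fold lower number from compound 2 to compound 4 (0.02 log units; within the scatter). Compound 4 is therefore estimated at 270 nM, with a range from 140 nM to 550 nM.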

Compound 4, half-maximal inhibitory concentration: 400 nM
Beside the measured number, compound 4's estimate is 1.5-fold (0.17 log units) below it, within the range that was stated.
By their numbers in this assay, from the lowest: compounds 3, 2, 1 and 4 (each within the scatter of the next).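

In this assay, methoxy in place of hydrogen on the aromatic carbon ortho to a methoxy group and para to a large group gives a 1.4-fold higher number from compound 2 to compound 4 (0.15 log units; within the scatter), so a single added methoxy at this position produces no step beyond the scatter. The reverse kind of change elsewhere on the core, hydrogen in place of methoxy, gives a 1.3-fold higher number from compound 1 to compound 4 (0.12 log units; within the scatter), and it too stays within the scatter, so neither single methoxy change separates these compounds. Nothing available explains where these numbers fall.

For the compounds shown here, what an amine, a carboxylic acid or a hydroxyl group would do at this position remains open, since methoxy is the only group here that replaces hydrogen there. Whether any change at this position can give a step beyond the scatter also remains unanswered.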